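This account rests on a few compounds, and the source may have more. Where it says the series, first, only, none or still open, it means among the compounds named here.

In an assay (Rattus norvegicus) for inhibition of Fatty-acid amide hydrolase 1 (Homo sapiens) (a higher number here means a weaker inhibitor, a lower number a stronger inhibitor), the three measured compounds give:

compound 1 `COC(=O)c1ccccc1-c1cnc(C(=O)CCCCCCc2ccccc2)o1`, 60 nM
compound 2 `O=C(CCCCCCc1ccccc1)c1ncc(-c2cccc(C(=O)C(F)(F)F)c2)o1`, 16 nM
compound 3 `Nc1ccc(-c2cnc(C(=O)CCCCCCc3ccccc3)o2)cc1`, 90 nM

Compound 3 stands at the highest of the three numbers. Its gap to compound 1 is within the scatter, so no order between the two is claimed; its gap to compound 2, which gives the lower number, is beyond the scatter. Compound 4 `O=C(CCCCCCc1ccccc1)c1ncc(-c2ncccn2)o1` has not been measured. It differs from compound 3 in one place: pyrimidin-2-yl in place of 4-aminophenyl on an aromatic carbon. For the measured compounds named here, no step between two measured compounds covers this exchange. The three measured variations of the group on this carbon span only a modest range, so the step in this assay from compound 3 to compound 4 is expected to be small, a 1.6-fold lower number from compound 3 to compound 4 (0.21 log units; within the scatter), not beyond the scatter. For compound 4 the estimate in this assay is 55 nM, expected between 15 nM and 180 nM.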

Compound 4, inhibition constant: 5.3 nM
Compound 4: middle estimate off by 10-fold (1.02 log units), on the high side; measured number below the stated range.
By their numbers in this assay, from the lowest: compound 4; then compound 2; then compounds 1 and 3 (each within the scatter of the next).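

In this assay, the group on this aromatic carbon next to the ring oxygen can shift the number strongly: a 17-fold lower number from compound 3 to compound 4 (1.23 log units; beyond the scatter). Compound 4 is also the only compound shown with hetero atoms in this six-membered ring, whereas compounds 1, 2 and 3 carry rings of carbon only. The data offer no explanation for this step.

This single exchange adds ring nitrogens and removes the amine together, so their contributions remain unseparated. Plain phenyl or pyridin-2-yl on the same carbon would help to separate them.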